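The source may hold more compounds than are shown below. What is called first, only, known or untested is meant among the compounds shown, and "the series" means these compounds.

In a physicochemical assay for lipophilicity, read by HPLC, measured as octanol-water partition, at pH 7.4 (a higher number here means a more lipophilic compound, a lower number a more polar compound), the measured compounds are: compound 1 `NC(=O)[C@@H](CCC(F)(F)F)N(C[C@H]1CCCCO1)S(=O)(=O)c1ccc(Cl)cc1` with 4.3; compound 2 `NC(=O)[C@@H](CCC(F)(F)F)N(C[C@H]1CCCOC1)S(=O)(=O)c1ccc(Cl)cc1` with 3.6.

Compound 2 stands lowest of the two numbers, its nearest neighbour being compound 1, with the step of a number 0.70 log units lower from compound 1 to compound 2 (beyond the scatter). Compound 3 `NC(=O)[C@@H](CCC(F)(F)F)N(C[C@H]1CCO1)S(=O)(=O)c1ccc(Cl)cc1` has not yet been measured in this assay. It differs from compound 2 thus: oxetan-2-yl in place of oxan-3-yl on a saturated chain carbon bound to a sulfonamide nitrogen. Among the measured compounds shown here, only one measured step bears on this position, a number 0.70 log units lower from compound 1 to compound 2 (beyond the scatter), and that exchanged one oxanyl ring for another, so it is a weak guide. The ring that enters is smaller, and a further fall beyond the scatter is expected, a number 0.90 log units lower from compound 2 to compound 3 (beyond the scatter). Compound 3 is therefore estimated at 2.7, within 2.2 to 3.2.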

Compound 3, distribution coefficient: 2.6
The estimate for compound 3 lay 0.10 log units above the measured number; measured number inside the range.
By their numbers in this assay, from the lowest: compound 3; then compound 2; then compound 1.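

The change to oxetan-2-yl gives a number 1.00 log units lower from compound 2 to compound 3 (beyond the scatter) in this assay, and measured against the other oxanyl ring it gives a number 1.70 log units lower from compound 1 to compound 3 (beyond the scatter). The earlier pair showed only an exchange between six-membered rings, whereas here the ring itself shrinks on a saturated chain carbon bound to a sulfonamide nitrogen, with the counts of hetero atoms and hydrogen-bond acceptors unchanged. No measurement given here accounts for these steps. The compounds shown leave open where a five-membered oxolanyl ring would fall, and whether an open ether chain would behave like the rings. As far as these compounds go, what a ring amine would do at this place also remains unknown.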